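Working notes: 2-chlorophenyl in place of 3,4-dichlorophenyl

The compounds below may be only part of what the source reports. "The series", "measured", "known", "first", "only" and "open" are said of these compounds alone.

- compound 1 `NC1=NC2(CCSCC2)N(OCCCOc2ccc(Cl)c(Cl)c2)C(N)=N1` gives 10 nM
- compound 2 `NC1=NC2(CCOCC2)N(OCCCOc2ccc(Cl)cc2)C(N)=N1` gives "not determined" (no result reported)

For the measured compounds named here, in a functional assay on MDA-MB-231 cells (Homo sapiens) for antiproliferative activity, read by MTT assay, with a stated time of 72 h (a higher number here means a weaker inhibitor, a lower number a stronger inhibitor), compound 1 gives 10 nM as the only number, so it cannot yet be ranked against anything. Going by the values given here, compound 2 offers no comparison, and no pair of measured compounds shows the size of any structural step.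

The next compound to be measured is compound 3 `NC1=NC2(CCSCC2)N(OCCCOc2ccccc2Cl)C(N)=N1`, which carries 2-chlorophenyl in place of 3,4-dichlorophenyl on an oxygen on a saturated carbon and keeps the core of compound 1. Among the compounds with values here, with no measured step as a guide, the expectation is a judgement with a wide margin. In this assay the expected step is a 4.0-fold higher number from compound 1 to compound 3 (0.60 log units; beyond the scatter) and it is estimated to lie beyond the scatter, towards weaker inhibition. Compound 3 is expected to give 40 nM (estimated range 8 nM to 200 nM).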

Compound 3, half-maximal inhibitory concentration: 80 nM
Compound 3: the middle estimate sits 2.0-fold (0.30 log units) below what was measured, within the range that was stated.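

In this assay, for the compounds shown here, the change to 2-chlorophenyl in place of 3,4-dichlorophenyl, on an oxygen on a saturated carbon, gives an 8.0-fold higher number from compound 1 to compound 3 (0.90 log units; beyond the scatter) and is the first step with a measured size. With the core of compound 1 kept, this single change in the aryl group moves the number beyond the usual scatter, towards weaker inhibition, so the result at this position depends on which chlorophenyl group is present. Nothing available explains the size of this step.

The compounds shown leave open how an unsubstituted phenyl or a 4-methoxyphenyl would compare at this position, and so whether any other aryl group can match 3,4-dichlorophenyl. They also leave open what a longer chain carrying the 3,4-dichlorophenyl would do.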